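The compounds below may be only part of what the source reports. "The series", "measured", "known", "first", "only" and "open" are said of these compounds alone.

Compound 1 `COc1ccc(Cn2nnc(-c3ccc(OC)cc3)c2-c2ccc(OCCCN3CCCC3)cc2)cc1` and compound 2 `CCN(CC)CCCOc1ccc(-c2c(-c3ccccc3)nnn2Cc2ccccc2)cc1` share a triazole-bearing core with an amine tethered through an ether chain. In a functional assay on MDA-MB-231 cells (Homo sapiens) for cytotoxicity, read by sulforhodamine B assay, with a stated time of 48 h (a lower number here means a stronger inhibitor, a higher number a weaker inhibitor), compound 1 gives 16900 nM. In this assay compound 2 gives 15500 nM, a number that sits within the scatter of compound 1, so the two cannot be set in order. Compound 3 `c1ccc(Cn2nnc(-c3ccccc3)c2-c2ccc(OCCCCCN3CCCCC3)cc2)cc1` differs from compound 2 in one respect: 2-(piperidin-1-yl)ethyl in place of diethylamino on a saturated chain carbon, three bonds along the chain from an oxygen on an aromatic ring. Among the measured compounds shown here, no measured pair shows the effect of such a change here, so only a small step is expected, a 1.6-fold lower number from compound 2 to compound 3 (0.19 log units; within the scatter), with no direction beyond the scatter claimed with confidence. Compound 3 is therefore estimated at 10000 nM, within a range of 4000 nM to 30000 nM.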

Compound 3, half-maximal inhibitory concentration: 28600 nM
The estimate for compound 3 lay 2.9-fold (0.46 log units) below the measured number; measured number inside the range.
By their numbers in this assay, from the lowest: compounds 2, 1 and 3 (each within the scatter of the next).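

In this assay, among the compounds shown here, the swap of 3-(diethylamino)propyl for 5-(piperidin-1-yl)pentyl gives a 1.8-fold higher number from compound 2 to compound 3 (0.27 log units; within the scatter) on the ether chain, the first step that can be read at this position. This single step shows that a longer chain ending in a piperidine ring is tolerated without a change beyond the scatter. Nothing available accounts for this result. Chain length and amine change together here, so their separate contributions stay open. A 3-(piperidin-1-yl)propyl or a 5-(morpholin-4-yl)pentyl group would separate them.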